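The source may report more compounds than this note shows. Statements on the series, on what has been measured and on what is new or still open speak of the compounds shown alone.

Compound 3 `COc1ccc(-c2cc(COc3ccccc3-c3nc4ccccc4s3)on2)cc1` is one of three close analogues built on a shared core. In a functional assay on A549 cells (Homo sapiens) for cytotoxicity, read by MTT assay, with a stated time of 24 h (on this read-out higher numbers stand for weaker inhibition and lower numbers for stronger inhibition), compound 3 gives 24100 nM. Compound 1 `COc1cc(-c2cc(COc3ccccc3-c3nc4ccccc4s3)on2)cc(OC)c1OC` gives 22900 nM in this assay, and compound 2 `Fc1ccccc1-c1cc(COc2ccccc2-c2nc3ccccc3s2)on1` gives 22500 nM, so all three numbers sit within the scatter of one another. Going by the values given here, the only single-point step measured, a 1.1-fold higher number from compound 2 to compound 3 (0.03 log units; within the scatter), swapped the whole aryl group and still stayed within the scatter. Compound 4 `Cc1ccc(-c2cc(COc3ccccc3-c3nc4ccccc4s3)on2)cc1` differs from compound 3 by methyl in place of methoxy on an aromatic carbon. Among the compounds with values here, no measured step covers this swap, but the one step available moved nothing beyond the scatter, so compound 4 is expected to give about 23000 nM, within 11000 nM to 46000 nM, a step of a 1.0-fold lower number from compound 3 to compound 4 (0.02 log units; within the scatter).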

Compound 4, half-maximal inhibitory concentration: 16400 nM
The estimate for compound 4 lay 1.4-fold (0.15 log units) above the measured number; measured number inside the range.
By their numbers in this assay, from the lowest: compounds 4, 2, 1 and 3 (each within the scatter of the next).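

Methyl in place of methoxy on this aromatic carbon, para to a large group, gives a 1.5-fold lower number from compound 3 to compound 4 (0.17 log units; within the scatter), so this first change confined to one substituent also stays within the scatter. The wider swap to 4-methylphenyl from 2-fluorophenyl gives a 1.4-fold lower number from compound 2 to compound 4 (0.14 log units; within the scatter), and all four aryl groups shown therefore remain within the scatter of one another. No supporting measurement is available to explain these close numbers. On these data alone, whether an amine or a carboxylic acid at this position would move the number beyond the scatter remains open. Also open, as far as these compounds go, is whether changes to the shared core would do so.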